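Hexylsulfanyl in place of the ether: cytotoxicity outlook

A few compounds are considered here, and "the series" means these few. Any claim that something is new, unique, unknown or untested is made for them only; others in the source may bear on it.

Three analogues sharing one core have been run in an ADME assay on MOLT-3 cells (Homo sapiens) for cytotoxicity, with a stated time of 7 days; on this read-out higher numbers stand for lower toxicity in this test and lower numbers for higher toxicity in this test. Compound 1 `CNc1nc(N)nc2c1ncn2/C=C1/CC1(CO)CO` carries a methylamino group; in this assay compound 1 gives > 20000 nM, which is a limit of the assay rather than a number. Compound 2 `COCCOc1nc(N)nc2c1ncn2/C=C1/CC1(CO)CO` carries a 2-methoxyethoxy group; in this assay compound 2 gives > 20000 nM, again a limit. Compound 3 `CCCCCCCCSc1nc(N)nc2c1ncn2/C=C1/CC1(CO)CO` carries an octylsulfanyl group; in this assay compound 3 gives > 20000 nM, also a limit. The steps among them, a step that the two limits leave unreadable from compound 1 to compound 2, a step that the two limits leave unreadable from compound 1 to compound 3 and a step that the two limits leave unreadable from compound 2 to compound 3, cannot be sized because of the limit of > 20000 nM in this assay, at which 3 of the 3 values shown sit. Compound 2 thus stands only at a limit, as do both of its neighbours.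

Compound 4 `CCCCCCSc1nc(N)nc2c1ncn2/C=C1/CC1(CO)CO` differs from compound 2 by hexylsulfanyl in place of 2-methoxyethoxy on an aromatic carbon. The step from compound 2 to compound 3, octylsulfanyl and hexylsulfanyl being chains of the same kind, is the nearest comparison, and it is unreadable. For the measured compounds named here, no step in this set is readable, so no direction can be taken from the data. The expected step that the limit leaves unreadable from compound 2 to compound 4 is therefore taken as none beyond the scatter. The estimate for compound 4 in this assay is 40000 nM, with an expected range from 15000 nM to 120000 nM.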

Compound 4, half-maximal cytotoxic concentration: > 20000 nM
Compound 4 gave a limit, no number; the forecaster's own chance of this, stated with the estimate: 85%; the middle value does not contradict the limit.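

Compound 4 joins compound 1, compound 2 and compound 3 at a limit in this assay, and no new step among these compounds can be read because none of them gives a number: the limit of > 20000 nM in this assay, at which 4 of the 4 values shown sit.

The compounds shown leave open whether methylamino, 2-methoxyethoxy, hexylsulfanyl or octylsulfanyl on the aromatic carbon makes any difference in this assay at all.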